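A few compounds are considered here, and "the series" means these few. Any claim that something is new, unique, unknown or untested is made for them only; others in the source may bear on it.

Within the data shown here, in a functional assay on OVCAR-3 cells (Homo sapiens) for antiproliferative activity, read by MTT assay, with a stated time of 24 h (on this read-out lower numbers stand for stronger inhibition and higher numbers for weaker inhibition), compound 1 `O=C(NNc1cccc(Cl)c1)c1ccc(NS(=O)(=O)c2cnc(O)nc2O)cc1` gives 8410 nM, the only actual number so far. Compound 2 `Cc1cccc(NNC(=O)c2cccc(NS(=O)(=O)c3cnc(O)nc3O)c2)c1` is reported only as a limit, > 20000 nM. Among the measured compounds shown here, compound 1 therefore has no measured neighbour to be ranked against, and no measured pair shows how a single change moves the result.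

Compound 3 `Cc1ccccc1C(=O)NNC(=O)c1ccc(NS(=O)(=O)c2cnc(O)nc2O)cc1` has not yet been tested. It keeps the core of compound 1 but carries (2-methylphenyl)carbonyl in place of 3-chlorophenyl on an amine nitrogen. The expected step in this assay, a 1.4-fold higher number from compound 1 to compound 3 (0.15 log units; within the scatter), stays within the usual scatter. This expectation rests on compound 1 at 8410 nM, a single number, so the uncertainty is wide. A reported limit rather than a number is also possible for compound 3. For compound 3 the estimated value is 12000 nM, with an expected range of 4000 nM to 30000 nM.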

Compound 3, half-maximal inhibitory concentration: > 20000 nM
Compound 3: a limit, no number (the forecaster's own chance of this, stated with the estimate: 35%); middle value at least 1.6-fold (0.22 log units) away from the limit.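

Among these compounds, this is the first change that can be read as a step: putting (2-methylphenyl)carbonyl in place of 3-chlorophenyl on an amine nitrogen gives, in this assay, an at least 2.3-fold higher number from compound 1 to compound 3 (0.37 log units; beyond the scatter), so inhibition at this position does depend on the group carried there. Compound 3 gives > 20000 nM, which is a limit of the assay and not a number. The step therefore has a lower bound but no known full size, because the read-out stops at this value for most of the compounds shown: the limit of > 20000 nM in this assay, at which 2 of the 3 values shown sit.

The change swaps several things at once, so the compounds shown leave open whether the added carbonyl, the methyl or the lost chlorine matters most. A (3-chlorophenyl)carbonyl group or a 2-methylphenyl group on the same nitrogen would help to separate these parts.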